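The source may report more compounds than this note shows. Statements on the series, on what has been measured and on what is new or still open speak of the compounds shown alone.

Measured in a functional assay on MT4 cells (Homo sapiens) for cytotoxicity; a higher number here means that more compound is tolerated, a lower number that less compound is tolerated:
compound 1 `Cc1nc(S)n(Nc2ccc(F)cc2)c1-c1ccccc1`: 220000 nM
compound 2 `COC(=O)C1C(C)N=C(S)N1Nc1cccc(Cl)c1`: 190000 nM
compound 3 `Cc1nc(S)n(Nc2cccc(Cl)c2)c1-c1ccc(Cl)cc1`: 40800 nM

Compound 1 and compound 2 lie within the usual scatter of each other, so these two cannot be ranked. Compound 3 lies beyond the scatter from compound 1, with a lower number, meaning that less of it is tolerated.

The next compound, compound 4 `Cc1nc(S)n(Nc2ccc(Cl)cc2)c1-c1ccccc1`, keeps the core of compound 1 and changes one group, 4-fluorophenyl to 4-chlorophenyl: chloro in place of fluoro on an aromatic carbon, para to a large group (chloro in place of fluoro on an aromatic carbon).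

The measured compounds give only a weak guide to this swap. Chloro is carried by compound 3, at 40800 nM, but also by compound 2, at 190000 nM, so its presence does not go with one outcome. A small move toward a lower number is expected, possibly none beyond the scatter.

The expected change is a 1.8-fold lower number from compound 1 to compound 4 (0.26 log units; within the scatter).

For compound 4 the estimated value in this assay is 120000 nM, with an expected range of 45000 nM to 250000 nM.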

Compound 4, half-maximal cytotoxic concentration: 134000 nM
The estimate for compound 4 lay 1.1-fold (0.05 log units) below the measured number; the measured number falls inside the stated range.
By their numbers in this assay, from the lowest: compound 3; then compounds 4, 2 and 1 (each within the scatter of the next).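

In this assay, putting chloro in place of fluoro on an aromatic carbon, para to a large group, gives a 1.6-fold lower number from compound 1 to compound 4 (0.22 log units; within the scatter). Among these compounds, this is the first pair in the set that differs in only one place, so the swap can be judged on its own, and at this position it does not separate the two halogens. No measurement shown here speaks to why the two compounds cannot be told apart.

As far as these compounds go, it remains open whether a different group at the same place, such as a methoxy group, an amine or a carboxylic acid, would move the number beyond the scatter. From the compounds shown here alone, it is also open whether chloro in place of fluoro would give an equally small step on a different core.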